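The source may report more compounds than this note shows. Statements on the series, on what has been measured and on what is new or still open speak of the compounds shown alone.

Of the compounds shown here, three built on the same core have been tested in a functional assay on HSC-4 cells (Homo sapiens) for cytotoxicity, with a stated time of 48 h; a lower number here means that less compound is tolerated, a higher number that more compound is tolerated. In this assay compound 1 `COc1ccc(/C=C/C(=O)c2c(C)[n+]([O-])c3ccccc3[n+]2[O-])cc1` gives 11000 nM, the second highest of the three numbers. Nearest to it is compound 3 `Cc1c(C(=O)/C=C/c2ccc(F)cc2)[n+]([O-])c2ccccc2[n+]1[O-]`, which in this assay gives 8100 nM; furthest is compound 2 `Cc1c(C(=O)/C=C/c2ccc(Cl)cc2)[n+]([O-])c2ccccc2[n+]1[O-]`, which gives 19000 nM. The step of a 1.4-fold lower number from compound 1 to compound 3 (0.13 log units; within the scatter) and the step of a 1.7-fold higher number from compound 1 to compound 2 (0.24 log units; within the scatter) both fall within the scatter, whereas the step of a 2.3-fold lower number from compound 2 to compound 3 (0.37 log units; beyond the scatter) is modest but beyond it.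

Compound 4 `Cc1c(C(=O)/C=C/c2ccc(Br)cc2)[n+]([O-])c2ccccc2[n+]1[O-]` has not yet been measured. It differs from compound 1 in one place: bromo in place of methoxy on an aromatic carbon. The measured steps that bear on this change are the two in which the methoxy of compound 1 is replaced by a halogen at the same place, namely a 1.7-fold higher number from compound 1 to compound 2 (0.24 log units; within the scatter) and a 1.4-fold lower number from compound 1 to compound 3 (0.13 log units; within the scatter); neither moved the number beyond the scatter. For compound 4 the step of a 1.4-fold higher number from compound 1 to compound 4 (0.13 log units; within the scatter) in this assay is therefore expected to be small, at most toward a somewhat higher number. Compound 4 is estimated to give about 15000 nM in this assay, with a likely range from 6000 nM to 40000 nM.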

Compound 4, half-maximal cytotoxic concentration: 36000 nM
Beside the measured number, compound 4's estimate is 2.4-fold (0.38 log units) below it; low and high end bracket the measured number.
By their numbers in this assay, from the lowest: compounds 3, 1, 2 and 4 (each within the scatter of the next, the first and the last beyond it).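

In this assay this position, where no earlier replacement of the methoxy had moved the number beyond the scatter, now shows one that does, with a 3.3-fold higher number from compound 1 to compound 4 (0.51 log units; beyond the scatter) when bromo enters on the aromatic carbon. For the compounds shown here, the halogens also separate further than the earlier compounds showed: a 4.4-fold higher number from compound 3 to compound 4 (0.65 log units; beyond the scatter) lies beyond the scatter, while a 1.9-fold higher number from compound 2 to compound 4 (0.28 log units; within the scatter) lies within it, so the position distinguishes fluoro from bromo but does not distinguish chloro from bromo. Nothing available explains why the number follows the group at this place in this way.

The compounds shown carry only methoxy and three halogens at this place, so it remains open how an amine, a carboxylic acid or a nitrile on the same carbon would read in this assay and whether the separation of fluoro from bromo would extend to such groups. Going by these compounds, it is also open whether the same replacements would give steps of similar size on another carbon of this ring, or in cells other than those of this single assay.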